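The source may hold more compounds than are shown below. What is called first, only, known or untested is meant among the compounds shown, and "the series" means these compounds.

Measured so far in an ADME assay on microsomes from liver (Homo sapiens) for metabolic stability, read by LC-MS, using NADPH, with stated times of 5 min and 30 min, tested at 1 uM; a lower number here means slower removal, a higher number faster removal of the compound:
- compound 1 `Cc1ncc(-c2cnc(NCc3c(F)ccc4c3CCO4)c3cn[nH]c(=O)c23)n1C`: 10 mL.min-1.g-1
- compound 2 `Cc1ncccc1-c1cnc(NCc2c(F)ccc3c2CCO3)c2cn[nH]c(=O)c12`: 41 mL.min-1.g-1

Compound 2, at 41 mL.min-1.g-1, holds the higher of these two numbers, so it is the faster removed. Compound 3 `CNC(=O)c1ccc(-c2cnc(NCc3c(F)ccc4c3CCO4)c3cn[nH]c(=O)c23)c(C)n1` keeps the shared core and changes one place: methylcarbamoyl in place of hydrogen on an aromatic carbon. In words, methylcarbamoyl stands in place of hydrogen on an aromatic carbon, next to the ring nitrogen. Going by the values given here, only one measured step bears on this, a 4.1-fold higher number from compound 1 to compound 2 (0.61 log units; beyond the scatter), which is modest but beyond the scatter. Among the compounds with values here, it swapped this whole aromatic group, so it shows that changes here can move this assay, but no measured step adds a group to this ring. The direction is therefore a tentative judgement. An estimated 1.6-fold lower number from compound 2 to compound 3 (0.21 log units; within the scatter) is expected, smaller than that measured step. The expected value for compound 3 is about 25 mL.min-1.g-1, within an estimated range of 10 mL.min-1.g-1 to 60 mL.min-1.g-1.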

Compound 3, intrinsic clearance in microsomes: 23 mL.min-1.g-1
Compound 3: middle estimate off by 1.1-fold (0.04 log units), on the high side; the measured number falls inside the stated range.
By their numbers in this assay, from the lowest: compound 1; then compounds 3 and 2 (each within the scatter of the next).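

Read in this assay the addition of methylcarbamoyl next to the ring nitrogen gives a 1.8-fold lower number from compound 2 to compound 3 (0.25 log units; within the scatter) and so cannot be told apart from hydrogen at this place, even though a group of 4 heavy atoms enters there. The whole-group exchange, 2-methyl-6-(methylcarbamoyl)pyridin-3-yl in place of 1,2-dimethyl-1H-imidazol-5-yl, gives a 2.3-fold higher number from compound 1 to compound 3 (0.36 log units; beyond the scatter) and so remains a real difference between these two aromatic groups. No measurement shown gives a cause for either step.

From the compounds shown here alone, whether an amine, a carboxylic acid or a longer chain at this place would also stay within the scatter of hydrogen remains open. So does whether methylcarbamoyl would read the same on a different aromatic group.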